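Trimming the Amide Substituent on a Kinase Inhibitor Core

The source may report more compounds than this note shows. Statements on the series, on what has been measured and on what is new or still open speak of the compounds shown alone.

Among three compounds measured in an assay for inhibition of serine/threonine-protein kinase PLK2 (Homo sapiens), read by FRET and Z'-LYTE, with a stated time of 1 h (on this read-out higher numbers stand for weaker inhibition and lower numbers for stronger inhibition), compound 3 `CCNC(=O)c1ccc2c(ccn2-c2ncc3c(n2)N(c2ccn(C)n2)C(CC)C(=O)N3C)c1` gives 243 nM, the second highest of the three numbers. Compound 1 `CCC1C(=O)N(C)c2cnc(-n3ccc4cc(C(=O)NC(C)C)ccc43)nc2N1c1ccn(C)n1` gives 125 nM, and the step of a 1.9-fold higher number from compound 1 to compound 3 (0.29 log units; within the scatter) lies within the scatter. Compound 2 `CCC1C(=O)N(C)c2cnc(-n3ccc4cc(F)ccc43)nc2N1c1ccn(C)n1` gives 1500 nM; here a 6.2-fold lower number from compound 2 to compound 3 (0.79 log units; beyond the scatter), while a 12-fold higher number from compound 1 to compound 2 (1.08 log units; beyond the scatter). Compound 4 `CCC1C(=O)N(C)c2cnc(-n3ccc4cc(C(N)=O)ccc43)nc2N1c1ccn(C)n1` differs from compound 3 by hydrogen in place of ethyl on an amide-type nitrogen. The step that bears most directly on this change is a 1.9-fold higher number from compound 1 to compound 3 (0.29 log units; within the scatter), a shortening of the same alkyl chain on the amide, which lay within the scatter; the carbamoyl group itself is what separates compound 2 from the other two. A further shortening is therefore expected to give only a small change in this assay, a 1.2-fold higher number from compound 3 to compound 4 (0.09 log units; within the scatter). Compound 4 is estimated at 300 nM, with a range from 120 nM to 800 nM.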

Compound 4, half-maximal inhibitory concentration: 384 nM
The estimate for compound 4 lay 1.3-fold (0.11 log units) below the measured number; the measured number falls inside the stated range.
By their numbers in this assay, from the lowest: compounds 1, 3 and 4 (each within the scatter of the next, the first and the last beyond it); then compound 2.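

With the ethyl gone from the amide-type nitrogen, compound 4 cannot be told apart from compound 3 in this assay (a 1.6-fold higher number from compound 3 to compound 4 (0.20 log units; within the scatter)), yet the two small steps together open a real gap from the isopropyl amide (a 3.1-fold higher number from compound 1 to compound 4 (0.49 log units; beyond the scatter)). The plain carbamoyl still separates from fluoro (a 3.9-fold lower number from compound 2 to compound 4 (0.59 log units; beyond the scatter)), so the carbamoyl alone, without any alkyl group on its nitrogen, keeps part of the difference. No evidence is available to explain these differences. Going by these compounds, whether a longer chain such as butyl, or a cyclopropyl group, on that nitrogen would extend the series remains open, as does the outcome of a carboxylic acid in place of the carbamoyl.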